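This account rests on a few compounds, and the source may have more. Where it says the series, first, only, none or still open, it means among the compounds named here.

Compound 2, `CC(=O)Nc1ccc(S(=O)(=O)NNc2ccc(F)c(Cl)c2)cc1`, is the anchor of this pair of notes. Within the data shown here, in an assay for inhibition of Indoleamine 2,3-dioxygenase 1 (Homo sapiens), read by spectrophotometry, with stated times of 1 h and 4 h (on this read-out higher numbers stand for weaker inhibition and lower numbers for stronger inhibition), compound 2 gives 110 nM, the lowest of the two numbers so far, with compound 1, `CC(=O)Nc1ccc(S(=O)(=O)NNc2ccc(F)c(Br)c2)cc1`, as its nearest neighbour. In this assay compound 1 gives 128 nM; the step of a 1.2-fold lower number from compound 1 to compound 2 (0.07 log units; within the scatter) is within the scatter, so the two compounds are not distinguished by this read-out.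

Compound 3, `CC(=O)Nc1ccc(S(=O)(=O)NNc2ccc(Cl)c(Cl)c2)cc1`, is the next in line. It departs from compound 2 by chloro in place of fluoro on an aromatic carbon; the chloro that enters is ortho to a chloro group and para to a large group.

Among the measured compounds shown here, the one step measured so far, from compound 1 to compound 2, exchanged one halogen for another on the same aromatic ring and produced no movement beyond the scatter. The present exchange is likewise one halogen for another on that ring. On that basis compound 3 is expected to stay close to compound 2 in this assay, with a step of about no change at the digits printed from compound 2 to compound 3 (within the scatter) that would not exceed the scatter. Compound 3 is estimated at 110 nM, with a range of 55 nM to 230 nM.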

Compound 3, half-maximal inhibitory concentration: 247 nM
Estimate against measurement, compound 3: 2.2-fold (0.35 log units) below; measured number above the stated range.
By their numbers in this assay, from the lowest: compounds 2, 1 and 3 (each within the scatter of the next, the first and the last beyond it).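

In this assay, among these compounds, the halogen para to a large group is the first place where a single exchange registers: chloro in place of fluoro gives a 2.2-fold higher number from compound 2 to compound 3 (0.35 log units; beyond the scatter) on the shared core. The earlier exchange at the other halogen-bearing carbon, a 1.2-fold lower number from compound 1 to compound 2 (0.07 log units; within the scatter) and no more, does not separate its pair, so the ring does not respond alike to every halogen exchange among the compounds shown. Among the compounds shown here, at this place fluoro carries the lower number of the two halogens compared, though that rests on the single pair of compound 2 and compound 3, and no available measurement bears on the origin of the step.

Still open, from the compounds shown here alone, is whether the number at this place follows the halogen further, as bromo or iodo would show, or whether a methoxy or an amine there would return to the level of compound 2 or go lower. All three compounds also keep the acetamide of the shared core, so what a carboxylic acid or a simple amine in its place would do in this assay remains an open question.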